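Side-chain amine change from compound 3 to compound 4

The source may hold more compounds than are shown below. What is called first, only, known or untested is meant among the compounds shown, and "the series" means these compounds.

- compound 1 `O=C1c2c[n+]([O-])c3ccccc3c2C(=O)c2c1c1ccccc1n2CCCCN1CCNCC1`: 1380 nM
- compound 2 `CCCN1CCN(CCCCn2c3c(c4ccccc42)C(=O)c2c[n+]([O-])c4ccccc4c2C3=O)CC1`: 6830 nM
- compound 3 `CN(C)CCCCn1c2c(c3ccccc31)C(=O)c1c[n+]([O-])c3ccccc3c1C2=O`: 300 nM

In a toxicity assay on L02 cells (Homo sapiens) for cytotoxicity, read by MTT assay, with a stated time of 72 h (a lower number here means a stronger inhibitor, a higher number a weaker inhibitor), compound 3 has the lowest number of the three, at 300 nM, and both other compounds lie beyond the scatter from it. The next structure, compound 4 `O=C1c2c[n+]([O-])c3ccccc3c2C(=O)c2c1c1ccccc1n2CCCN1CCC(O)CC1`, carries 4-hydroxypiperidin-1-yl in place of (dimethylamino)methyl on a saturated chain carbon, three bonds along the chain from an aromatic nitrogen.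

Among the measured compounds shown here, two measured steps bear on this change: a 4.6-fold lower number from compound 1 to compound 3 (0.66 log units; beyond the scatter), with dimethylamino in place of piperazin-1-yl, and a 23-fold lower number from compound 2 to compound 3 (1.36 log units; beyond the scatter), with dimethylamino in place of 4-propylpiperazin-1-yl. Both compounds carrying a six-membered ring amine have higher numbers than the dimethylamino compound. For the measured compounds named here, no measured compound carries 4-hydroxypiperidin-1-yl, so this read-across is loose. A modest move to a higher number in this assay is expected, closer to the first of those steps than to the second. The expected step is a 3.3-fold higher number from compound 3 to compound 4 (0.52 log units; beyond the scatter). For compound 4 the estimate is 1000 nM, with an expected range of 300 nM to 3500 nM.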

Compound 4, half-maximal inhibitory concentration: 120 nM
Beside the measured number, compound 4's estimate is 8.3-fold (0.92 log units) above it; the whole stated range lies above it.
By their numbers in this assay, from the lowest: compound 4; then compound 3; then compound 1; then compound 2.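

In this assay a six-membered ring amine on the chain no longer goes with a higher number than the dimethylamino compound: the change gives a 2.5-fold lower number from compound 3 to compound 4 (0.40 log units; beyond the scatter) and reverses the direction seen with piperazin-1-yl and 4-propylpiperazin-1-yl. The steps of a 12-fold lower number from compound 1 to compound 4 (1.06 log units; beyond the scatter) and a 57-fold lower number from compound 2 to compound 4 (1.76 log units; beyond the scatter) show that compound 4 stands well apart from both piperazine compounds, and it has the lowest number of the four. The change from 4-(dimethylamino)butyl to 3-(4-hydroxypiperidin-1-yl)propyl alters the amine and the chain together, so these compounds cannot separate the two.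

From the compounds shown here alone, it remains open how much of the step belongs to the hydroxyl and how much to the shorter chain, which an unsubstituted piperidine on the propyl chain or 4-hydroxypiperidin-1-yl on the butyl chain could address. Nothing available explains why compound 4 has the lowest number.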